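Fluoro for Bromo on the Benzyl Ester of Compound 2

This account rests on a few compounds, and the source may have more. Where it says the series, first, only, none or still open, it means among the compounds named here.

Measured compounds in a functional assay on K562 cells (Homo sapiens) for inhibition, read by luminescence, with a stated time of 72 h, tested at 5 uM; a higher number here means more inhibition of growth at the concentration tested, a lower number less inhibition of growth:
Compound 1, `COc1cc(O)c(C(=O)OC(C)C)c(/C=C/CN2C(=O)C=CC2=O)c1`, gives 95.7%.
Compound 2, `C=CS(=O)(=O)NC/C=C/c1cc(OC)cc(O)c1C(=O)OCc1ccc(Br)cc1`, gives 38.4%.
Compound 3, `COc1cc(O)c(C(=O)OCC(C)c2ccccc2)c(/C=C/CN2C(=O)C=CC2=O)c1`, gives 74.9%.

Compound 2 stands lowest of the three numbers; compound 3 is nearest to it and compound 1 furthest, both gaps lying beyond the scatter. Compound 4, `C=CS(=O)(=O)NC/C=C/c1cc(OC)cc(O)c1C(=O)OCc1ccc(F)cc1`, differs from compound 2 in one place: fluoro in place of bromo on an aromatic carbon.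

For the measured compounds named here, only one measured step is available, a number 20.8 percentage points lower from compound 1 to compound 3 (beyond the scatter), and it concerns the alcohol part of the ester, not a halogen on the benzyl ring. Going by the values given here, no measured pair shows what fluoro in place of bromo does here, so nothing in these data supports a step in either direction. Among the compounds with values here, the expectation is therefore a change within the scatter, a number 0.4 percentage points lower from compound 2 to compound 4 (within the scatter), with the estimate for compound 4 in this assay placed at 38%, ranging from 18% to 60%, the wide range reflecting that no comparable step has been measured.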

Compound 4, percent growth inhibition at one concentration: 52%
For compound 4 the middle estimate is 14 percentage points below the measured one, within the range that was stated.
By their numbers in this assay, from the lowest: compound 2; then compound 4; then compound 3; then compound 1.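

In this assay fluoro in place of bromo gives a number 13.6 percentage points higher from compound 2 to compound 4 (beyond the scatter) and so shows that this aromatic carbon, para to a large group, is not a silent place: a swap of one halogen for another, with no ring, donor, acceptor or charge entering or leaving, is enough to move the number. The earlier step concerned only the alcohol part of the ester as a whole, whereas this one shows that a single atom on the 4-bromobenzyl group also counts. Nothing measured here accounts for the rise from 4-bromobenzyl to 4-fluorobenzyl.

The compounds shown leave open what chloro, methoxy or plain hydrogen would give at this place on the ring. They also leave open whether 4-fluorobenzyl would bring a similar step on the ester of compound 1.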